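A few compounds are considered here, and "the series" means these few. Any claim that something is new, unique, unknown or untested is made for them only; others in the source may bear on it.

Measured compounds:
- compound 1 `C=CC(=O)N1CC[C@H](N2C(=O)N(c3ccccc3)Cc3cnc(Nc4cccc(N5CCN(C)CC5)c4)nc32)C1`: 20%
- compound 2 `C=CC(=O)N1CC[C@H](N2C(=O)N(c3ccccc3)Cc3cnc(Nc4ccc(N5CCN(C)CC5)cc4OC)nc32)C1`: 44%

Both compounds share one core and were tested in an ADME assay on the whole organism (strain Sprague-Dawley) for pharmacokinetics, with Rattus norvegicus as the target, read by LC-MS, at a dose of 25 mg/kg by the oral route; a higher number here means that a larger share of the oral dose reaches the circulation, a lower number that a smaller share of the oral dose reaches the circulation. In this assay compound 2 gives 44%, the higher of the two numbers, while compound 1 gives 20%, a difference that lies beyond the usual scatter. Compound 1 and compound 2 differ in more than one place, so their gap cannot be tied to a single change.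

Compound 3 `C=CC(=O)N1CC[C@H](N2C(=O)N(c3ccccc3)Cc3cnc(Nc4ccc(N5CCN(C)CC5)cc4)nc32)C1` is not yet measured. It differs from compound 2 in one place: hydrogen in place of methoxy on an aromatic carbon. The methoxy group sits ortho to a large group and meta to the 4-methylpiperazin-1-yl group. Going by the values given here, no pair of measured compounds isolates this change, so there is no direct guide to its size. A modest drop is expected, and the step from compound 2 is estimated as a number 12 percentage points lower from compound 2 to compound 3 (beyond the scatter), which is small enough that it could fall within the scatter. Compound 3 is therefore expected to give about 32% in this assay, with a likely range from 14% to 52%.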

Compound 3, oral bioavailability: 54%
Compound 3: the middle estimate sits 22 percentage points below what was measured; the measured number lies above the stated range.
By their numbers in this assay, from the lowest: compound 1; then compounds 2 and 3 (each within the scatter of the next).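

Going by these compounds alone, compound 2 and compound 3 are the first pair in this set that differ in one place only, so a single change can be read on its own in this assay. Putting hydrogen in place of methoxy on the aromatic carbon that is ortho to a large group and meta to a 4-methylpiperazin-1-yl group gives a number 10 percentage points higher from compound 2 to compound 3 (within the scatter) and so shows that the methoxy group is not needed at this carbon for this read-out, since the two numbers cannot be told apart. Nothing among the data shown offers an explanation for this result.

What remains open is whether this carbon tolerates other groups equally well, such as fluorine, a methyl group, a longer ether like ethoxy, or an amine, since methoxy and hydrogen are the only two shown there. This single pair also cannot tell whether the same swap would behave the same way on a compound with the 4-methylpiperazin-1-yl group placed differently, as it is in compound 1.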